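A few compounds are considered here, and "the series" means these few. Any claim that something is new, unique, unknown or untested is made for them only; others in the source may bear on it.

Among the measured compounds shown here, compound 2 `COc1ccc(Cn2c(CCc3ccccc3)nnc2[C@H](NC(=O)c2cnccn2)c2c[nH]c3ccccc23)cc1` is the only compound here that comes with a number: in a functional assay on CHO cells for antagonist activity at growth hormone secretagogue receptor type 1 (Homo sapiens) (a higher number here means a weaker inhibitor, a lower number a stronger inhibitor), compound 2 gives 530 nM. Compound 1 `CCc1ccc(Cn2c(CCc3ccccc3)nnc2[C@H](NC(=O)c2ccncc2)c2c[nH]c3ccccc23)cc1`, which already carries the 4-ethylbenzyl group, has in this assay only the entry "not determined" (no result reported), so it offers no guide. Compound 3 `CCc1ccc(Cn2c(CCc3ccccc3)nnc2[C@H](NC(=O)c2cnccn2)c2c[nH]c3ccccc23)cc1` differs from compound 2 in one place: ethyl in place of methoxy on an aromatic carbon. For the measured compounds named here, no measured pair shows this change, so the expected step of a 1.1-fold lower number from compound 2 to compound 3 (0.03 log units; within the scatter) is small, within the usual scatter and in no set direction. Compound 3 is therefore expected to give about 500 nM, between 200 nM and 1500 nM.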

Compound 3, antagonist equilibrium constant: 76 nM
Beside the measured number, compound 3's estimate is 6.6-fold (0.82 log units) above it; measured number outside the range, below it.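

In this assay, going from 4-methoxybenzyl to 4-ethylbenzyl gives a 7.0-fold lower number from compound 2 to compound 3 (0.84 log units; beyond the scatter) and so shows that this aromatic carbon is sensitive to what it carries, even when the two groups have the same heavy-atom count. The ethyl group also lacks the hydrogen-bond acceptor of the methoxy group, but no measurement shown links that difference to the stronger inhibition, and nothing here explains the change.

This single pair leaves open how a longer chain such as propyl, a chlorine atom or an amine at this position would compare.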